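This account rests on a few compounds, and the source may have more. Where it says the series, first, only, none or still open, it means among the compounds named here.

Measured in a functional assay on HeLa cells (Homo sapiens) for cytotoxicity, read by MTT assay, in the presence of a further agent that is not named here; on this read-out lower numbers stand for stronger inhibition and higher numbers for weaker inhibition:
- compound 1 `O=C1CC(CCc2ccccc2)[S+]([O-])S1`: 24800 nM
- compound 2 `CC(C)(C)[Si](C)(C)O[C@@H]1[C@H](O[Si](C)(C)C(C)(C)C)[C@@H](C2CC(=O)S[S+]2[O-])O[C@H]1n1ccc(=O)[nH]c1=O`: 2670 nM
- compound 3 `Cc1cn([C@H]2C[C@H](O[Si](C)(C)C(C)(C)C)[C@@H](C3CC(=O)S[S+]3[O-])O2)c(=O)[nH]c1=O`: 6610 nM

Compound 3, at 6610 nM, holds the middle place among these three values. Its number is higher than that of compound 2, at 2670 nM, and lower than that of compound 1, at 24800 nM. Both gaps lie beyond the scatter.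

Next in line is compound 4 `Cc1cn([C@H]2C[C@H](O)[C@@H](C3CC(=O)S[S+]3[O-])O2)c(=O)[nH]c1=O`, still unmeasured in this assay. The change from compound 3 is a hydrogen atom in place of a group of 7 heavy atoms (6 carbon, 1 silicon; no ring), on an oxygen on a saturated carbon: a hydrogen atom takes the place of a group of 7 heavy atoms on an oxygen on a saturated carbon.

Among the compounds with values here, no measured pair differs in one place only, so the size of this step has no direct precedent. Within the data shown here, the only guide is indirect. Compounds 2 and 3 both carry the group and have the lower numbers, whereas compound 1 lacks it and stands at 24800 nM, though its core also differs. On that weak basis, weaker inhibition is expected, with a step beyond the scatter.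

The expected step is a 4.2-fold higher number from compound 3 to compound 4 (0.63 log units; beyond the scatter).

The estimate for compound 4 is 28000 nM, with an expected range of 10000 nM to 80000 nM.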

Compound 4, half-maximal inhibitory concentration: 29700 nM
For compound 4 the middle estimate is 1.1-fold (0.03 log units) below the measured one; the range from low to high includes it.
By their numbers in this assay, from the lowest: compound 2; then compound 3; then compounds 1 and 4 (each within the scatter of the next).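

In this assay the series gains its first comparison that differs in one place only: a hydrogen atom in place of the group of 7 heavy atoms (6 carbon, 1 silicon; no ring), on an oxygen on a saturated carbon, gives a 4.5-fold higher number from compound 3 to compound 4 (0.65 log units; beyond the scatter) as a modest step beyond the scatter. The earlier compounds shown here differed in more than one place and could not isolate this group, whereas this pair shows that, on this core, the change at this oxygen alone moves the read-out toward weaker inhibition. No measurement shown here accounts for the size or the direction of this step.

The compounds shown leave open where a methyl ether, an acetyl ester or a trimethylsilyl group on the same oxygen would fall relative to the hydrogen atom and the larger group. Also open, going by these compounds, is whether the same exchange gives a step of similar size on the core of compound 2, and whether an amine in place of that oxygen would keep the number of compound 4 or shift it.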